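The source may hold more compounds than are shown below. What is called first, only, known or untested is meant among the compounds shown, and "the series" means these compounds.

Of the compounds shown here, two built on a shared core have been tested in an ADME assay on cells (Homo sapiens) for cytotoxicity, read by polymerase chain reaction, with a stated time of 3 days; a higher number here means that more compound is tolerated, a lower number that less compound is tolerated. Compound 1 `Nc1nc(Cl)c(-c2cc3ccccc3s2)c(N[C@@H]2C[C@H](CO)[C@@H](O)[C@H]2O)n1` gives > 25000 nM in this assay, a limit of the measurement rather than a number. Compound 2 `CNc1nc(C)c(-c2nc3ccccc3s2)c(N[C@@H]2C[C@H](CO)[C@@H](O)[C@H]2O)n1` gives > 25000 nM in this assay, again a limit. Going by the values given here, compound 2 thus stands at the limit of > 25000 nM in this assay, at which 2 of the 2 values shown sit, and no step between measured compounds can be read off, since neither of them yields a number to compare.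

Compound 3 `Cc1nc(NCCNC(=O)NC(C)(C)C)nc(N[C@@H]2C[C@H](CO)[C@@H](O)[C@H]2O)c1-c1nc2ccccc2s1` differs from compound 2 in one place, namely (((tert-butyl)carbamoyl)amino)methyl in place of hydrogen on a saturated chain carbon bound to a nitrogen on an aromatic ring and nothing else. The (((tert-butyl)carbamoyl)amino)methyl group takes the place of a hydrogen on a saturated chain carbon bound to a nitrogen on an aromatic ring.

With both measured compounds sitting at the limit, there is no measured change to lean on. Compound 3 is expected to remain tolerated at the same limit. The step that the limit leaves unreadable from compound 2 to compound 3 is therefore expected to be none beyond the scatter. Compound 3 is estimated at 30000 nM with an expected range from 10000 nM to 100000 nM, and it may well be that this expected value again lies at the limit.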

Compound 3, half-maximal cytotoxic concentration: > 25000 nM
Compound 3 gave a limit, no number; the forecaster's own chance of this, stated with the estimate: 75%; the middle value lies beyond the limit too.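

In this assay compound 3 gives > 25000 nM, a limit and not a number. Going by these compounds alone, compound 2 also sits at a limit, so no step from compound 2 to compound 3 can be read. The compounds shown leave open at what concentration, if any, each one harms the cells, and whether the (((tert-butyl)carbamoyl)amino)methyl group changes that: the limit of > 25000 nM in this assay, at which 3 of the 3 values shown sit.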